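Urea aryl swap on compound 3: expectation for compound 4

This account rests on a few compounds, and the source may have more. Where it says the series, first, only, none or still open, it means among the compounds named here.

Three compounds have numbers in a functional assay on NCI-H226 cells (Homo sapiens) for inhibition, read by MTT assay, with a stated time of 48 h, tested at 10 uM; a higher number here means more inhibition at the concentration tested (going by the name of the read-out), a lower number less inhibition. Compound 1 `COc1cc(NC(=O)Nc2cc(Nc3ccc(OC)c(C)c3)ncn2)cc(OC)c1` gives 39.7%, compound 2 `COc1cc(NC(=O)Nc2cc(Nc3ccc(OC)c(I)c3)ncn2)cc(OC)c1` gives 40.1%, and compound 3 `CC(C)(C)c1ccc(Nc2cc(NC(=O)Nc3c(Cl)cccc3Cl)ncn2)cc1` gives 40%. Among the compounds with values here, the single one-point step measured so far, a number 0.4 percentage points higher from compound 1 to compound 2 (within the scatter), lies within the scatter. Compound 3 stands second highest of the three numbers, with compound 2 nearest and compound 1 furthest, both gaps within the scatter, so the three numbers cannot be told apart.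

Compound 4 `COc1cc(NC(=O)Nc2cc(Nc3ccc(C(C)(C)C)cc3)ncn2)cc(OC)c1` differs from compound 3 in one place: 3,5-dimethoxyphenyl in place of 2,6-dichlorophenyl on an amide-type nitrogen. Within the data shown here, no measured step covers this change; the only step known, from compound 1 to compound 2, concerns a different position and is itself within the scatter. What can be drawn on is that compound 1 and compound 2 already carry the 3,5-dimethoxyphenyl group on an amide-type nitrogen and give numbers indistinguishable from compound 3, which carries the 2,6-dichlorophenyl group there. The expectation for compound 4 in this assay is therefore a step of no change at the digits printed from compound 3 to compound 4 (within the scatter), none beyond the scatter. Compound 4 is estimated at 40%, with a range from 25% to 55%.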

Compound 4, a percentage reported as inhibition, at one concentration (the size of the read-out at that concentration, not a potency): 47.7%
Compound 4: middle estimate off by 7.7 percentage points, on the low side, within the range that was stated.
By their numbers in this assay, from the lowest: compounds 1, 3, 2 and 4 (each within the scatter of the next).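

Working notes: in this assay the swap of 2,6-dichlorophenyl for 3,5-dimethoxyphenyl on an amide-type nitrogen, now read directly for the first time, gives a number 7.7 percentage points higher from compound 3 to compound 4 (within the scatter) and so does not separate the two groups. At the other place, on a nitrogen on an aromatic ring, 4-(tert-butyl)phenyl in place of 3-iodo-4-methoxyphenyl gives a number 7.6 percentage points higher from compound 2 to compound 4 (within the scatter) and 4-(tert-butyl)phenyl in place of 4-methoxy-3-methylphenyl gives a number 8 percentage points higher from compound 1 to compound 4 (within the scatter) as the matching readings. None of these three steps leaves the scatter, so neither place has yet been shown to move this read-out, and these aryl groups remain interchangeable at this level of resolution.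

Open, going by these compounds, is whether an amine or a carboxylic acid on the amide-type nitrogen, or a morpholine in place of 4-(tert-butyl)phenyl on the nitrogen on an aromatic ring, would give a step beyond the scatter. Nothing available bears on why these four numbers sit so close together.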